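The source may report more compounds than this note shows. Statements on the series, on what has been measured and on what is new or still open speak of the compounds shown alone.

Compound 1 `N#C/C(=C\N1CCN(C(=O)c2ccco2)C1=S)C(=O)Nc1ccc(Cl)cc1` and compound 2 `N#C/C(=C\N1CCN(C(=O)c2ccco2)C1=S)C(N)=O` share one core and differ only at the amide-type nitrogen. In a functional assay on K562 cells (Homo sapiens) for inhibition, read by sulforhodamine B assay, with a stated time of 48 h (a higher number here means a weaker inhibitor of growth, a lower number a stronger inhibitor of growth), compound 1 gives 16100 nM, while compound 2 gives 9100 nM. The step of a 1.8-fold lower number from compound 1 to compound 2 (0.25 log units; within the scatter) shows that removing the 4-chlorophenyl group from that nitrogen left the growth-inhibiting power essentially where it was. For the measured compounds named here, compound 2 is one of only two measured compounds, and the gap between its number and that of compound 1 lies within the scatter, so neither can be called the stronger inhibitor on this evidence.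

Compound 3 `N#C/C(=C\N1CCN(C(=O)c2ccco2)C1=S)C(=O)c1ccccc1` is the next, unmeasured, member. Compared with compound 2 the change is phenyl in place of amino on a carbonyl carbon, so the carbamoyl group becomes a benzoyl group. Going by the values given here, the only measured step bears on this indirectly: it concerned a substituent on the amide nitrogen rather than the carbonyl carbon, and it moved the number by no more than the scatter. With nothing suggesting a large shift, the step of a 1.2-fold higher number from compound 2 to compound 3 (0.08 log units; within the scatter) from compound 2 to compound 3 is expected to stay within the scatter, and compound 3 is estimated at 11000 nM in this assay, with a likely range from 4000 nM to 30000 nM.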

Compound 3, concentration for 50% growth inhibition: 5500 nM
Compound 3: middle estimate off by 2.0-fold (0.30 log units), on the high side, within the range that was stated.
By their numbers in this assay, from the lowest: compounds 3, 2 and 1 (each within the scatter of the next, the first and the last beyond it).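

In this assay, the carbonyl carbon accepts a phenyl group directly on it: replacing amino gives a 1.7-fold lower number from compound 2 to compound 3 (0.22 log units; within the scatter), so on these numbers growth inhibition does not depend on keeping a nitrogen at this place. Replacing (4-chlorophenyl)amino gives a 2.9-fold lower number from compound 1 to compound 3 (0.47 log units; beyond the scatter), a modest step but the first among these compounds to pass the scatter, which shows that a change on this carbonyl carbon can move the number measurably. No measurement here accounts for either step.

The step from compound 1 to compound 3 removes the chlorine and the nitrogen together, so these compounds cannot show which of the two matters; a 4-chlorobenzoyl group, with the chlorine kept and the nitrogen gone, would separate them. Also open, going by these compounds, is how smaller or differently built groups on the same carbon, such as a methyl group or the hydroxyl of a carboxylic acid, would compare with phenyl and amino.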